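Bromo to nitro on the benzylthio arm

A few compounds are considered here, and "the series" means these few. Any claim that something is new, unique, unknown or untested is made for them only; others in the source may bear on it.

Measured so far:
compound 1, `Fc1ccccc1CSc1nnc(-c2ccncc2)n1-c1ccccc1`, > 50000 nM
compound 2, `Brc1ccc(CSc2nnc(-c3ccncc3)n2-c2ccccc2)cc1`, 12600 nM

Among the measured compounds shown here, in a functional assay on MCF7 cells (Homo sapiens) for inhibition, read by MTT assay, with a stated time of 48 h (a lower number here means a stronger inhibitor, a higher number a weaker inhibitor), compound 2 gives 12600 nM, the only number in the set so far. For compound 1 the value > 50000 nM is a limit of the assay and not a number (the limit of > 50000 nM in this assay, at which 1 of the 2 values shown sits). For the measured compounds named here, the one measured step, an at least 3.9-fold lower number from compound 1 to compound 2 (0.59 log units; beyond the scatter), changes the ring on the saturated chain carbon bound to sulfur, so it does not touch the kind of change now at hand.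

Compound 3 is `O=[N+]([O-])c1ccc(CSc2nnc(-c3ccncc3)n2-c2ccccc2)cc1`. It differs from compound 2 by nitro in place of bromo on an aromatic carbon. Going by the values given here, no measured step exchanges one group for another at this position, so no step bears directly on it; the change is expected to stay within the scatter or to reach at most a modest shift in either direction.

The expected step is a 1.3-fold lower number from compound 2 to compound 3 (0.10 log units; within the scatter), the sign being uncertain. Compound 3 is estimated at 10000 nM, with a range from 3000 nM to 40000 nM.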

Compound 3, half-maximal inhibitory concentration: 22800 nM
The estimate for compound 3 lay 2.3-fold (0.36 log units) below the measured number; the measured number falls inside the stated range.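

In this assay, nitro in place of bromo on the aromatic carbon para to a large group gives a 1.8-fold higher number from compound 2 to compound 3 (0.26 log units; within the scatter), so the two groups cannot be told apart at this place. 4-Nitrophenyl in place of 2-fluorophenyl gives an at least 2.1-fold lower number from compound 1 to compound 3 (0.34 log units; beyond the scatter), so the lower number seen earlier with 4-bromophenyl is not confined to that one group. This step rests on compound 1, whose value is a limit and not a number: the limit of > 50000 nM in this assay, at which 1 of the 3 values shown sits.

Open, from the compounds shown here alone, is whether the gap to compound 1 follows the place on the ring or the group itself, as both change together in each step from that compound. Also open, going by these compounds, is how an amine or a carboxylic acid at this place would read in this assay.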